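The source may report more compounds than this note shows. Statements on the series, on what has been measured and on what is new or still open speak of the compounds shown alone.

Of the compounds shown here, three built on one shared core have been tested in an assay on isolated protein for binding affinity to melatonin receptor type 1A (Homo sapiens); on this read-out higher numbers stand for weaker inhibition and lower numbers for stronger inhibition. Compound 1 `CCCC(=O)Nc1cccc(Oc2cccc(OC)c2)c1` gives only a limit of the measurement rather than a number: in this assay compound 1 reaches > 500 nM. Compound 2 `CCCC(=O)Nc1ccc(Oc2cccc(OC)c2)cc1` gives 63 nM in this assay. Compound 3 `CCC(=O)Nc1ccc(Oc2cccc(OC)c2)cc1` gives 300 nM in this assay, and of the two full numbers it is the higher one, which here means the weaker binding. Going by the values given here, the only measured step that joins it to another number is a 4.8-fold higher number from compound 2 to compound 3 (0.68 log units; beyond the scatter), so shortening the chain on the carbonyl carbon by one carbon cost binding modestly.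

Compound 4 `C/C=C/C(=O)Nc1ccc(Oc2cccc(OC)c2)cc1` differs from compound 3 in a single place: prop-1-en-1-yl in place of ethyl on a carbonyl carbon. The chain on the carbonyl carbon thus returns to three carbons, as in compound 2, but now carries a double bond outside the aromatic rings. Among the compounds with values here, the step from compound 2 to compound 3 is the one measured change that bears on this, and it suggests that putting the third carbon back should lower the number again, though the double bond is untested here. Compound 4 is therefore expected to bind more strongly than compound 3, with a step of a 3.0-fold lower number from compound 3 to compound 4 (0.48 log units; beyond the scatter), giving an estimate of 100 nM, most likely between 40 nM and 300 nM.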

Compound 4, inhibition constant: 98 nM
For compound 4 the middle estimate is 1.0-fold (0.01 log units) above the measured one; the range from low to high includes it.
By their numbers in this assay, from the lowest: compounds 2 and 4 (each within the scatter of the next); then compound 3. At a limit, above all of these: compound 1.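

Prop-1-en-1-yl in place of ethyl on the carbonyl carbon gives a 3.1-fold lower number from compound 3 to compound 4 (0.49 log units; beyond the scatter) in this assay and so shows that a chain of three carbons here can carry a double bond and still bind more strongly than the ethyl chain. Prop-1-en-1-yl in place of propyl gives a 1.6-fold higher number from compound 2 to compound 4 (0.19 log units; within the scatter) and so leaves compound 2 and compound 4 indistinguishable in this measurement. Until now only the length of this chain had been varied, whereas this result shows that a double bond outside the aromatic rings can enter it with no change beyond the scatter, and the two chains of three carbons now read alike while the ethyl chain of compound 3 stands apart.

Still open, from the compounds shown here alone, is whether a longer chain such as pentyl, a small ring such as cyclopropyl, or a chain ending in an amine or a carboxylic acid would serve as well on the carbonyl carbon, and whether the opposite geometry of the double bond would read the same. Nothing shown here explains why the chain length matters at this position or why the double bond leaves the reading within the scatter.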